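A few compounds are considered here, and "the series" means these few. Any claim that something is new, unique, unknown or untested is made for them only; others in the source may bear on it.

Among the measured compounds shown here, compound 2 `CCCCCCC(Sc1nc(Cl)cc(Nc2nc(-c3ccc([N+](=O)[O-])cc3)cs2)n1)C(=O)O` gives 1800 nM in an assay for inhibition of Polyunsaturated fatty acid 5-lipoxygenase (Homo sapiens), read by HPLC, with a stated time of 10 min (a higher number here means a weaker inhibitor, a lower number a stronger inhibitor), the lower of the two numbers measured so far, although compound 1 `CCCCCCC(Sc1nc(Cl)cc(Nc2nc(-c3ccc(F)cc3F)cs2)n1)C(=O)O` gives 2500 nM and the gap between them sits within the scatter. Compound 3 `CCCCCCC(Sc1nc(Cl)cc(Nc2nc(-c3ccc(Cl)cc3Cl)cs2)n1)C(=O)O` has not yet been measured; it differs from compound 2 by 2,4-dichlorophenyl in place of 4-nitrophenyl on an aromatic carbon. For the measured compounds named here, the only measured step that bears on this change is the exchange of the group on that aromatic carbon, a 1.4-fold lower number from compound 1 to compound 2 (0.14 log units; within the scatter), which lies within the scatter. Because the two aryl variants already seen gave numbers within the scatter of one another, a 1.4-fold lower number from compound 1 to compound 2 (0.14 log units; within the scatter), the step to compound 3 in this assay is expected to be small and probably not beyond the scatter, a 1.1-fold higher number from compound 2 to compound 3 (0.05 log units; within the scatter). On that basis compound 3 is estimated at 2000 nM, with a range from 800 nM to 5000 nM.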

Compound 3, half-maximal inhibitory concentration: 1100 nM
Beside the measured number, compound 3's estimate is 1.8-fold (0.26 log units) above it; the range from low to high includes it.
By their numbers in this assay, from the lowest: compounds 3, 2 and 1 (each within the scatter of the next, the first and the last beyond it).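

In this assay, the exchange of 4-nitrophenyl for 2,4-dichlorophenyl on this aromatic carbon, a 1.6-fold lower number from compound 2 to compound 3 (0.21 log units; within the scatter), does not separate the two compounds. Among the compounds shown here, the exchange of 2,4-difluorophenyl for 2,4-dichlorophenyl, a 2.3-fold lower number from compound 1 to compound 3 (0.36 log units; beyond the scatter), is the first step at this position to clear the scatter, which shows that the aryl group here can move the number, if only modestly, while compound 2 remains within the scatter of both other compounds. Nothing given here accounts for this step.

The compounds shown carry only three substituted phenyl groups at this position, so it remains open how an unsubstituted phenyl would compare. Going by these compounds, it also remains open whether an amine or a methoxy group on that phenyl ring would move the number further in either direction.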